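Cyclohexylmethyl amide as a variant of a weak cytotoxin

The source may hold more compounds than are shown below. What is called first, only, known or untested is meant among the compounds shown, and "the series" means these compounds.

Measured compounds:
compound 1 `CCc1ccc(NC(=O)c2cccc(/C=C3\CC(=O)N(c4ccccc4)C3=O)c2)cc1`: > 100000 nM
compound 2 `CCCCCN1C(=O)C/C(=C\c2cccc(C(=O)Nc3cccc(CC)c3)c2)C1=O`: 83300 nM
compound 3 `COc1ccc(NC(=O)c2cccc(/C=C3\CC(=O)N(c4ccc(C)cc4)C3=O)c2)cc1`: 93000 nM

In an ADME assay on SW480 cells (Homo sapiens) for cytotoxicity, read by MTT assay, with a stated time of 72 h (on this read-out lower numbers stand for stronger inhibition and higher numbers for weaker inhibition), compound 2 gives 83300 nM and compound 3 gives 93000 nM. Compound 1 reaches only > 100000 nM in this assay, which is a limit rather than a number, as the line the limit of > 100000 nM in this assay, at which 1 of the 3 values shown sits, records. Compound 1 therefore stands at the limit, with no measured number of its own. Compound 4 `O=C(NCC1CCCCC1)c1cccc(/C=C2\CC(=O)N(c3ccccc3)C2=O)c1` differs from compound 1 by cyclohexylmethyl in place of 4-ethylphenyl on an amide-type nitrogen. For the measured compounds named here, no pair of measured compounds differs in one place, so no step size is known from the data. The step in this assay is expected to be none beyond the scatter, and compound 4 may again stop at the limit. Compound 4 is estimated at 100000 nM, within 55000 nM to 200000 nM. That amounts to an expected a number no higher from compound 1 to compound 4 (the limit leaves the size open).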

Compound 4, half-maximal inhibitory concentration: > 100000 nM
Compound 4: no number, only a limit; the forecaster's own chance of this, stated with the estimate: 50%; the middle value lies on the limit itself.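

In this assay, compound 1 and compound 4 both stop at a limit rather than a number, so no step can be read between them. The compounds shown leave open whether cyclohexylmethyl in place of 4-ethylphenyl changes cytotoxicity at all.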